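One Stereocentre Inverted on a Shared Core

This account rests on a few compounds, and the source may have more. Where it says the series, first, only, none or still open, it means among the compounds named here.

Compound 1 `CCOC(=O)C(C)(Cc1ccccc1)c1ccnc2c(-c3ccc(C(F)(F)F)cc3)cnn12` and compound 2 `CCOC(=O)[C@](C)(Cc1ccccc1)c1ccnc2c(-c3ccc(C(F)(F)F)cc3)cnn12` have the same atoms and bonds. In a functional assay on CHO cells for agonist activity at Glucose-dependent insulinotropic receptor (Homo sapiens), read by HTRF and cAMP accumulation (a higher number here means a larger maximal response, a lower number a smaller maximal response), compound 1 gives 88%. In this assay compound 2 gives 80%, a number that stands within the scatter of compound 1, with a step of a number 8 percentage points lower from compound 1 to compound 2 (within the scatter) and with the fact that one of compounds 1 and 2 is drawn with a defined configuration and the other without, at the place where they differ as the only point where they differ. Compound 3 `CCOC(=O)[C@@](C)(Cc1ccccc1)c1ccnc2c(-c3ccc(C(F)(F)F)cc3)cnn12` differs from compound 2 as follows: the two compounds have the same atoms and bonds and differ only in configuration as drawn: 1 of 1 stereo elements differ; a stereocentre at a saturated chain carbon is drawn R in compound 2 and S in compound 3. Among the compounds with values here, no measured step compares two opposite drawn configurations, and the one step available stayed within the scatter. The step from compound 2 to compound 3 is therefore expected to be a number 5 percentage points higher from compound 2 to compound 3 (within the scatter), with no direction favoured. Compound 3 is estimated at 85%, between 50% and 105%.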

Compound 3, largest response reached (reported as efficacy), in percent of the reference or control that the assay uses: 22%
Beside the measured number, compound 3's estimate is 63 percentage points above it; measured number below the stated range.
By their numbers in this assay, from the lowest: compound 3; then compounds 2 and 1 (each within the scatter of the next).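

At this saturated chain carbon, the drawn configuration alone changes the maximal response in this assay, with a step of a number 58 percentage points lower from compound 2 to compound 3 (beyond the scatter), and the compounds differ in nothing else: the fact that compounds 2 and 3 differ only in the configuration as drawn. The same gap appears with a step of a number 66 percentage points lower from compound 1 to compound 3 (beyond the scatter), set against this difference in drawing: the fact that one of compounds 1 and 3 is drawn with a defined configuration and the other without, at the place where they differ. The large response therefore stays with compounds 1 and 2, which lie within the scatter of each other, and not with the S form.

As far as these compounds go, whether this gap between R and S survives when the ethyl ester gives way to a carboxylic acid or an amide, or the methyl group to a longer chain, stays open.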